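This account rests on a few compounds, and the source may have more. Where it says the series, first, only, none or still open, it means among the compounds named here.

Measured so far:
- compound 1, `COc1ccc(CO/N=C/c2c(C)nn(C)c2Oc2ccc(Cl)cc2)cc1`: 37%
- compound 2, `Cc1nn(-c2ccccc2)c(Oc2ccc(Cl)cc2)c1/C=N/OCc1ccc(C(=O)OC(C)(C)C)cc1`: -8.4%

In a functional assay on MCF7 cells (Homo sapiens) for antiproliferative activity, tested at 1 uM (on this read-out higher numbers stand for more inhibition at the one concentration tested (going by the name of the read-out) and lower numbers for less inhibition), compound 1 gives 37%, the higher of the two numbers. Compound 2 gives -8.4%, a number that sits beyond the usual scatter below compound 1. For the measured compounds named here, the two structures differ in several places at once, so no single-change step between measured compounds is available, and the gap between them cannot be tied to any one group.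

Compound 3, `Cc1ccc(CO/N=C/c2c(C)nn(C)c2Oc2ccc(Cl)cc2)cc1`, is not yet measured. It differs from compound 1 in one place only: methyl in place of methoxy on an aromatic carbon. The methoxy that leaves and the methyl that enters are both small groups on the same aromatic carbon, and the rest of the molecule is unchanged. Nothing in the measured pair shows how this assay responds to such a swap, so the step is expected to be modest: a small drop or none beyond the scatter. The step from compound 1 to compound 3 is estimated at a number 7 percentage points lower from compound 1 to compound 3 (within the scatter). Compound 3 is therefore expected to give about 30% in this assay, with a plausible range from 10% to 50%.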

Compound 3, a percentage reported as inhibition, at one concentration (the size of the read-out at that concentration, not a potency): 30.7%
Compound 3: middle estimate off by 0.7 percentage points, on the low side; measured number inside the range.
By their numbers in this assay, from the lowest: compound 2; then compounds 3 and 1 (each within the scatter of the next).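

In this assay, for the compounds shown here, placing methyl in place of methoxy on this aromatic carbon, para to a large group, gives a number 6.3 percentage points lower from compound 1 to compound 3 (within the scatter), and this is the only single-change comparison available so far. At this position, then, 4-methoxybenzyl and 4-methylbenzyl cannot be told apart in this read-out, and the methoxy oxygen, the one hydrogen-bond acceptor counted in the group that leaves, can go without a shift beyond the usual scatter. No measurement at hand explains this result, and a single step within the scatter cannot by itself show whether the group on this carbon matters at all.

As far as these compounds go, only these two small, uncharged groups have been seen on this carbon, so it remains open how an amine, a carboxylic acid, a longer chain such as butoxy, or a bare hydrogen would read there. From the compounds shown here alone, it also remains open whether the same swap would behave the same way with other groups elsewhere on the molecule, as this one step rests on a single pair sharing the core of compound 1.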